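This account rests on a few compounds, and the source may have more. Where it says the series, first, only, none or still open, it means among the compounds named here.

Measured in a functional assay on HL-60 cells (Homo sapiens) for cytotoxicity, read by MTT assay, with a stated time of 72 h; a higher number here means a weaker inhibitor, a lower number a stronger inhibitor
- compound 1 `Cc1ccc(S(=O)(=O)c2nc3ccccc3nc2N2CCCC2)cc1` gives 9720 nM
- compound 2 `O=S(=O)(c1ccc(Br)cc1)c1nc2ccccc2nc1N1CCCC1` gives 6070 nM

Within the data shown here, compound 2 stands within the scatter of compound 1, the only other compound measured, so the two cannot be ranked. Compound 3 `O=S(=O)(c1ccc(F)cc1)c1nc2ccccc2nc1N1CCCC1` has no measured value yet. Its difference from compound 2 reads (fluoro in place of bromo on an aromatic carbon). In words, this is fluoro in place of bromo on an aromatic carbon.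

Among the measured compounds shown here, one measured step bears on this change, and it concerns the same kind of exchange, bromo in place of methyl on an aromatic carbon. For the measured compounds named here, no compound with fluoro has been measured, so the evidence is thin. With only a 1.6-fold lower number from compound 1 to compound 2 (0.20 log units; within the scatter) to go on, no step beyond the scatter is expected for compound 3 in this assay and no firm direction can be given. The estimated change is a 1.2-fold higher number from compound 2 to compound 3 (0.09 log units; within the scatter) and it is expected to remain a small one. Compound 3 is estimated at 7500 nM and 3500 nM to 16000 nM is the expected range.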

Compound 3, half-maximal inhibitory concentration: 12800 nM
Compound 3: middle estimate off by 1.7-fold (0.23 log units), on the low side; low and high end bracket the measured number.
By their numbers in this assay, from the lowest: compounds 2, 1 and 3 (each within the scatter of the next, the first and the last beyond it).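

In this assay, among these compounds, the exchange of 4-bromophenyl for 4-fluorophenyl gives the first step at this place, on an aromatic carbon para to a large group, that lies beyond the scatter, though only modestly: a 2.1-fold higher number from compound 2 to compound 3 (0.32 log units; beyond the scatter). The methyl group, by contrast, cannot be separated from either halogen: its step to bromo was already within the scatter, and its step to fluoro is too, a 1.3-fold higher number from compound 1 to compound 3 (0.12 log units; within the scatter), so this position can be said to respond only in the comparison of bromo with fluoro, where one halogen atom replaces another with no change in the counted donors, acceptors or charge. Nothing available accounts for the difference between these two halogens.

From the compounds shown here alone, it remains open whether chloro or a plain hydrogen on this aromatic carbon would fall within the narrow span of these three compounds, and whether an amine, a carboxylic acid or a methoxy group there would move the number further in either direction. All three compounds also share the rest of the structure, so they leave open how a change elsewhere on the shared core would compare with this small step.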